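Removing a Methyl From a Ring Nitrogen in Two Cores

A few compounds are considered here, and "the series" means these few. Any claim that something is new, unique, unknown or untested is made for them only; others in the source may bear on it.

Of the compounds shown here, three have been tested in an assay on isolated protein for inhibition of RAC-alpha serine/threonine-protein kinase (Homo sapiens), read by mobility shift assay, tested at 30 uM; a higher number here means more inhibition at the concentration tested (going by the name of the read-out), a lower number less inhibition. Compound 1 `COc1ccc(-c2cc3[nH]nc(N)c3c(=O)[nH]2)cc1` gives 21%. Compound 2 `COc1ccc(-c2cc3c(c(N)nn3C)c(=O)[nH]2)cc1` gives 9% in this assay. Compound 3 `Cc1cc2c(cn1)c(N)nn2C` gives 0% in this assay, the lowest of the three numbers; its gap to compound 2 lies within the scatter, while its gap to compound 1 lies beyond it.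

Compound 1 and compound 2 differ in one place: hydrogen in place of methyl on an aromatic nitrogen. This change made a number 12 percentage points higher from compound 2 to compound 1 (beyond the scatter), a modest step.

Compound 4 `Cc1cc2[nH]nc(N)c2cn1` has not yet been measured. It differs from compound 3 by the same change: hydrogen in place of methyl on an aromatic nitrogen. The cores of compound 3 and compound 2 differ, but that difference is not broken down here.

Going by the values given here, the only guide to what this change does is the measured step of a number 12 percentage points higher from compound 2 to compound 1 (beyond the scatter). Among the compounds with values here, the expected step is a number 8 percentage points higher from compound 3 to compound 4 (within the scatter), estimated somewhat smaller than the measured one because compound 3 starts from 0% on a core that is not the one of compound 2. Compound 4 is therefore expected to give about 8%, estimated to fall between 0% and 20%.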

Compound 4, a percentage reported as inhibition, at one concentration (the size of the read-out at that concentration, not a potency): -1%
Compound 4: middle estimate off by 9 percentage points, on the high side; the measured number lies below the stated range.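

Replacing the methyl on the aromatic nitrogen with hydrogen gives in this assay a number 1 percentage points lower from compound 3 to compound 4 (within the scatter) on the core of compound 3, so no effect of the change can be told from the scatter on this core. Set beside the earlier result, the two steps cannot be told apart either: the same change on two cores in this assay, a number 12 percentage points higher (beyond the scatter) from compound 2 to compound 1 and a number 1 percentage points lower (within the scatter) from compound 3 to compound 4, 13 percentage points apart, within the scatter of two such steps. Whether the change carries from one core to another therefore stays undecided: the data do not show that it carries over or that it fails to, and with compound 3 at 0% and compound 4 at -1% this core shows little room for any step to be seen.

The compounds shown leave open what an ethyl group or a longer chain on that ring nitrogen would do, and whether the modest step seen on the core of compound 1 would return on a third core. They also leave open what a carboxylic acid in place of the amino group would do on either core.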